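The source may report more compounds than this note shows. Statements on the series, on what has been measured and on what is new or still open speak of the compounds shown alone.

Measured so far in a functional assay on L1210 cells (Mus musculus) for antiproliferative activity; a higher number here means a more potent compound, by a factor of ten per unit of this negative logarithm, a lower number a less potent compound:
compound 1, `Cc1nc(/N=N/N(C)C)c(C(N)=O)[nH]1`: 3.06
compound 2, `CCN(C)/N=N/c1ccc(C(N)=O)cc1`: 3.66
compound 3, `CCCc1nc(/N=N/N(C)C)c(C(N)=O)[nH]1`: 3.42

Compound 1 and compound 3 share one core and differ in one place: ethyl in place of hydrogen on a saturated chain carbon bound to an aromatic carbon. That change made a step of a number 0.36 log units higher from compound 1 to compound 3 (beyond the scatter) in this assay. Compound 2 is built on a different core; the difference between the two cores is not broken down here. Compound 2 and compound 3 lie within the scatter of each other in this assay, while compound 2 stands beyond the scatter above compound 1.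

Compound 4, `CCCCN(C)/N=N/c1ccc(C(N)=O)cc1`, has not yet been measured. It differs from compound 2 in one place: ethyl in place of hydrogen on a saturated chain carbon, two bonds along the chain from an amine nitrogen. The group that leaves and the group that enters are the same as between compound 1 and compound 3, but the place is not: there the saturated chain carbon is bound to an aromatic carbon, here it sits two bonds along the chain from an amine nitrogen. It is therefore the same kind of change, not the same change, and among these compounds it has been measured only once.

The expectation rests on that single step, a number 0.36 log units higher from compound 1 to compound 3 (beyond the scatter), read across to the other core with added uncertainty. A step of a number 0.29 log units higher from compound 2 to compound 4 (within the scatter) in this assay is expected from compound 2 to compound 4. For compound 4 the estimate in this assay is 3.95, with a range from 3.5 to 4.4.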

Compound 4, logarithm of the reciprocal of the active concentration, log(1/C): 3.47
Beside the measured number, compound 4's estimate is 0.48 log units above it; the measured number lies below the stated range.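

Ethyl in place of hydrogen on a saturated chain carbon, two bonds along the chain from an amine nitrogen, gave a number 0.19 log units lower from compound 2 to compound 4 (within the scatter) in this assay. Set beside the earlier step, the same kind of change did not keep its size from one core to the other: the same change on two cores in this assay, a number 0.36 log units higher (beyond the scatter) from compound 1 to compound 3 and a number 0.19 log units lower (within the scatter) from compound 2 to compound 4, 0.55 log units apart, beyond the scatter of two such steps The two steps also differ in place, one on a saturated chain carbon bound to an aromatic carbon and the other two bonds along the chain from an amine nitrogen, so with a single step on each core these numbers do not separate the effect of the core from that of the place, and they give no reason for the gap and no rule for any further core.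

The compounds shown leave open how a propyl chain or a longer chain such as hexyl at this place would stand against compound 2 and compound 4, and so whether chain length follows any trend on this core. They also leave open whether a carboxylic acid in place of the amide would change the result of this same chain extension on either core.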